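The compounds below may be only part of what the source reports. "The series", "measured", "known", "first", "only" and "open" are said of these compounds alone.

Measured so far:
- Compound 1, `O=C(O)[C@@H]1CCCN1C(=O)CN(c1nc(Cl)nc2[nH]cnc12)C1CC1`: 23.6%
- Compound 2, `CC[C@H](C)[C@H](NC(=O)CN(c1nc(Cl)nc2[nH]cnc12)C1CC1)C(=O)O`: 21.4%
- Compound 3, `C[C@@H](O)[C@H](NC(=O)CN(c1nc(Cl)nc2[nH]cnc12)C1CC1)C(=O)O`: 37.6%

These three compounds share one core and were tested in a functional assay on the whole organism (Tail, strain ICR) with Mus musculus as the target, in the tail flick test, with a stated time of 120 min, at a dose of 25 umol/kg by the oral route; on this read-out higher numbers stand for a stronger effect at the one dose given and lower numbers for a weaker effect. Compound 3 stands highest of the three: the step of a number 14 percentage points higher from compound 1 to compound 3 (beyond the scatter) and the step of a number 16.2 percentage points higher from compound 2 to compound 3 (beyond the scatter) both lie beyond the scatter, so compound 3 is the strongest of the measured set.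

The next compound, compound 4, `CC(C)[C@H](NC(=O)CN(c1nc(Cl)nc2[nH]cnc12)C1CC1)C(=O)O`, has not been measured. It differs from compound 3 in one place: isopropyl in place of 1-hydroxyethyl on a saturated chain carbon bound to an amide-type nitrogen and a carbonyl carbon. The 1-hydroxyethyl group of compound 3 leaves, and an isopropyl group enters at the saturated chain carbon bound to an amide-type nitrogen and a carbonyl carbon.

Among the measured compounds shown here, one measured step bears on this. In compound 2 an ethyl group sits where compound 3 carries a hydroxy, and the step of a number 16.2 percentage points higher from compound 2 to compound 3 (beyond the scatter) was a modest rise. Compound 4 goes back to an all-carbon side chain much like compound 2, so the reverse is expected: a modest drop in this assay, beyond the scatter, landing near the value of compound 2.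

For compound 4 the expected step is a number 14.6 percentage points lower from compound 3 to compound 4 (beyond the scatter), giving an estimate of 23%, with a range from 10% to 36%.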

Compound 4, a percentage reported as activity, at one dose (the size of the read-out at that dose, not a potency): 17.1%
Estimate against measurement, compound 4: 5.9 percentage points above, within the range that was stated.
By their numbers in this assay, from the lowest: compounds 4, 2 and 1 (each within the scatter of the next); then compound 3.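

In this assay, replacing 1-hydroxyethyl with isopropyl removes a hydrogen-bond donor and a hydrogen-bond acceptor while keeping the same count of heavy atoms, and the result is a number 20.5 percentage points lower from compound 3 to compound 4 (beyond the scatter); this direct swap at the saturated chain carbon bound to an amide-type nitrogen and a carbonyl carbon sets the hydroxy-bearing side chain of compound 3 apart from a close all-carbon match. The side chains without a hydroxy cannot be told apart here: removing a methyl from the chain gives a number 4.3 percentage points lower from compound 2 to compound 4 (within the scatter) and exchanging the 2-carboxypyrrolidin-1-yl group for (1-carboxy-2-methylpropyl)amino gives a number 6.5 percentage points lower from compound 1 to compound 4 (within the scatter), so the shape of these chains makes no readable difference in this small set. No measurement shown gives a reason for the gap between compound 3 and the other three compounds.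

The compounds shown leave open whether another group on this side chain, such as an amine or a methoxy, would behave like the hydroxy. A longer chain ending in a hydroxy is also an open case, as is the other spatial arrangement at the hydroxy-bearing carbon.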